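This account rests on a few compounds, and the source may have more. Where it says the series, first, only, none or still open, it means among the compounds named here.

In a functional assay on OVCAR-3 cells (Homo sapiens) for antiproliferative activity, read by MTT assay, with a stated time of 24 h (a lower number here means a stronger inhibitor, a higher number a weaker inhibitor), compound 1 `O=C(NNc1cccc(Cl)c1)c1cccc(NS(=O)(=O)c2cnc(O)nc2O)c1` gives 8040 nM. Compound 2 `O=C(NNc1ccccc1F)c1cccc(NS(=O)(=O)c2cnc(O)nc2O)c1` differs from it by 2-fluorophenyl in place of 3-chlorophenyl on an amine nitrogen, and in this assay compound 2 gives 17000 nM, a step of a 2.1-fold higher number from compound 1 to compound 2 (0.33 log units; beyond the scatter). Compound 3 `O=C(NNc1cccc(Cl)c1)c1ccccc1NS(=O)(=O)c1cnc(O)nc1O` is made of the same atoms as compound 1, joined differently; the difference between the two cores is not broken down here. In this assay compound 3 gives 5520 nM, the lowest of the three numbers, though its gap to compound 1 lies within the scatter. Compound 4 `O=C(NNc1ccccc1F)c1ccccc1NS(=O)(=O)c1cnc(O)nc1O` has not yet been measured. It differs from compound 3 by 2-fluorophenyl in place of 3-chlorophenyl on an amine nitrogen, the same change in the same place as before. For compound 4 the expected step is a 2.1-fold higher number from compound 3 to compound 4 (0.32 log units; beyond the scatter), resting on the single earlier case a 2.1-fold higher number from compound 1 to compound 2 (0.33 log units; beyond the scatter). Compound 4 is therefore estimated at 11500 nM, likely between 5000 nM and 27000 nM.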

Compound 4, half-maximal inhibitory concentration: 9570 nM
Beside the measured number, compound 4's estimate is 1.2-fold (0.08 log units) above it; measured number inside the range.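

In this assay, placing 2-fluorophenyl where 3-chlorophenyl stood gives a 1.7-fold higher number from compound 3 to compound 4 (0.24 log units; within the scatter), and the two cores agree on the size of this change: the same change on two cores in this assay, a 2.1-fold higher number (0.33 log units; beyond the scatter) from compound 1 to compound 2 and a 1.7-fold higher number (0.24 log units; within the scatter) from compound 3 to compound 4, 1.2-fold (0.09 log units) apart, within the scatter of two such steps. The step therefore carried from the core of compound 1 to the core of compound 3 with no difference that can be told apart, although on the second core it does not stand clear of the scatter. Two pairs do not show that it would hold on further cores, and they do not explain it.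

The compounds shown leave open how the series responds to anything other than these two halogenated phenyl groups on the amine nitrogen. On these data alone, a methyl group or a longer alkyl chain at that place, for example, remains untested here.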